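A few compounds are considered here, and "the series" means these few. Any claim that something is new, unique, unknown or untested is made for them only; others in the source may bear on it.

In a functional assay on KB cells (Homo sapiens) for cytotoxicity (a higher number here means a weaker inhibitor, a lower number a stronger inhibitor), compound 2, `O=S(=O)(N/C(=N\O)Nc1ccc(Cl)cc1)c1ccccc1`, gives 46 ug/mL, level with compound 1, `Cc1ccc(S(=O)(=O)N/C(=N\O)Nc2ccc(Cl)cc2)cc1`, at 46 ug/mL, while compound 3, `O=S(=O)(N/C(=N\O)Nc1ccc(Cl)cc1)c1ccc(-c2cccs2)cn1`, at 61 ug/mL, remains within the scatter of compound 2. Compound 4, `N#Cc1c(Cl)cccc1Oc1ccc(S(=O)(=O)N/C(=N\O)Nc2ccc(Cl)cc2)cc1`, differs from compound 2 by 3-chloro-2-cyanophenoxy in place of hydrogen on an aromatic carbon, which places 3-chloro-2-cyanophenoxy in place of hydrogen on an aromatic carbon, para to a large group. Among the compounds with values here, the only measured step, no change at the digits printed from compound 1 to compound 2 (within the scatter), involves a far smaller change and lies within the scatter. Within the data shown here, no measured step tests this group, so the expectation remains loose. No shift beyond the scatter is expected, and the estimated step is a 1.2-fold lower number from compound 2 to compound 4 (0.06 log units; within the scatter). For compound 4 the expected value is 40 ug/mL, with an estimated range from 15 ug/mL to 90 ug/mL.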

Compound 4, half-maximal inhibitory concentration: 39 ug/mL
For compound 4 the middle estimate is 1.0-fold (0.01 log units) above the measured one; the range from low to high includes it.
By their numbers in this assay, from the lowest: compounds 4, 1, 2 and 3 (each within the scatter of the next).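

In this assay, the change to 3-chloro-2-cyanophenoxy on an aromatic carbon, para to a large group, gives a 1.2-fold lower number from compound 2 to compound 4 (0.07 log units; within the scatter), and the change from methyl at the same place gives a 1.2-fold lower number from compound 1 to compound 4 (0.07 log units; within the scatter). This place therefore accepts a group of 10 heavy atoms with no shift beyond the scatter, which the small step between hydrogen and methyl could not show. No evidence is available to explain this result. The compounds shown leave open how an amine, a carboxylic acid or plain phenoxy would read at this place.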